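The source may report more compounds than this note shows. Statements on the series, on what has been measured and on what is new or still open speak of the compounds shown alone.

Measured so far:
- Compound 1 `COc1cc2cc[nH]c2cc1-c1ccncc1` gives 2 nM in an assay for antagonist activity at Toll-like receptor 8 (Homo sapiens), read by TR-FRET; a higher number here means a weaker inhibitor, a lower number a stronger inhibitor.
- Compound 2 `COc1cc2c(C(=O)N3CCN(C)CC3)n[nH]c2cc1-c1ccncc1` gives 39 nM in this assay.

Compound 2 has the higher of the two numbers. Going by the values given here, the only other measured compound, compound 1, sits at a value well outside the usual scatter of this assay, so the two are clearly apart; they differ from each other in more than one place, and what the two values show is all that can be said about them.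

Compound 3 `COc1cc2c(C(=O)N3CCN(C)CC3)n[nH]c2cc1-c1ccnc(C)c1F` is the unmeasured compound that grows out of compound 2. The change is a group of 8 heavy atoms (6 carbon, 1 nitrogen, 1 fluorine; one six-membered aromatic ring with 1 hetero atom) in place of a group of 6 heavy atoms (5 carbon, 1 nitrogen; one six-membered aromatic ring with 1 hetero atom), on an aromatic carbon. Among the compounds with values here, the shared core is kept, and no measured pair shows this particular swap, so there is nothing to calibrate its size against. A step of modest size is therefore expected, in either direction, and quite possibly none beyond the scatter. For compound 3 the estimate is 30 nM, within a range from 10 nM to 100 nM. The step this estimate means is a 1.3-fold lower number from compound 2 to compound 3 (0.11 log units; within the scatter), expected to stay close to the scatter.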

Compound 3, half-maximal inhibitory concentration in the Toll-like receptor 8 assay: 14 nM
Beside the measured number, compound 3's estimate is 2.1-fold (0.33 log units) above it, and the stated range covers the measured number.
By their numbers in the Toll-like receptor 8 assay, from the lowest: compound 1; then compound 3; then compound 2.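

In the Toll-like receptor 8 assay, putting the larger group with its fluorine in place of pyridin-4-yl gives a 2.8-fold lower number from compound 2 to compound 3 (0.44 log units; beyond the scatter). This position, ortho to a methoxy group, therefore accepts extra atoms on the six-membered aromatic ring with 1 hetero atom, and here they go with stronger inhibition rather than a loss of it. The same swap also changes how readily a proton is given up in a physicochemical assay for acid dissociation, which shows that this one change alters more than the size of the group: the measured acid dissociation constant of compound 2, 5.3, and of compound 3, 3.7, a number 1.60 log units lower (beyond the scatter). In the physicochemical assay compound 2 gives 5.3 and compound 3 gives 3.7.

The fluorine and the added carbon enter together, and with a single pair the compounds shown cannot tell which of the two accounts for the step, or whether the shift in the physicochemical assay has anything to do with the gain in the Toll-like receptor 8 assay. A ring carrying only the fluorine or only the added carbon, or one carrying a chlorine or an amine instead, would begin to separate these possibilities and show how much more this position can accept.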